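Piperidinyl for methoxyethylamino on a pyrazolopyridine core

A few compounds are considered here, and "the series" means these few. Any claim that something is new, unique, unknown or untested is made for them only; others in the source may bear on it.

Of the compounds shown here, three share a fused core and have been tested in an assay on isolated protein for inhibition of MAP kinase-activated protein kinase 2 (Homo sapiens), read by mobility shift assay, tested at 30 uM; on this read-out higher numbers stand for more inhibition at the one concentration tested (going by the name of the read-out) and lower numbers for less inhibition. Compound 1 `Cc1cc2c(c(N)nn2C)c(N2CC[C@H](O)C2)n1` gives 2% in this assay. Compound 2 `COCCNc1nc(C)cc2nn(-c3ccccc3)c(N)c12` gives 3% in this assay, and compound 3 `COc1ccccc1-c1cc2nn(-c3ccccc3)c(N)c2c(=O)[nH]1` gives -1% in this assay. Compound 2 thus stands alongside the other two, with both of their numbers lying within the usual scatter of its own, so none of the three can be told apart. Compound 4 `Cc1cc2nn(-c3ccccc3)c(N)c2c(N2CCCCC2)n1` has not yet been measured in this assay. It differs from compound 2 in one place: piperidin-1-yl in place of (2-methoxyethyl)amino on an aromatic carbon. With all three measured values sitting near zero, the step is expected to be small in either direction, and the estimated step of no change at the digits printed from compound 2 to compound 4 (within the scatter) stays within the scatter. Compound 4 is therefore expected to give about 3% in this assay, between -8% and 14%.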

Compound 4, a percentage reported as inhibition, at one concentration (the size of the read-out at that concentration, not a potency): 7%
Beside the measured number, compound 4's estimate is 4 percentage points below it; low and high end bracket the measured number.
By their numbers in this assay, from the lowest: compounds 3, 1, 2 and 4 (each within the scatter of the next).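

Swapping the open-chain (2-methoxyethyl)amino for the ring of piperidin-1-yl on this aromatic carbon next to the ring nitrogen gives a number 4 percentage points higher from compound 2 to compound 4 (within the scatter) in this assay. This position therefore accepts a six-membered non-aromatic ring in place of the chain, and losing the hydrogen-bond donor of the amino group does not set the two compounds apart. Nothing measured here bears on why the step is this size. Still open, going by these compounds, is whether morpholin-4-yl, a primary amine or a carboxylic acid on this carbon would give a number beyond the scatter of compound 2.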